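Azepan-1-yl in place of piperidin-1-yl: compound 3 to compound 4

A few compounds are considered here, and "the series" means these few. Any claim that something is new, unique, unknown or untested is made for them only; others in the source may bear on it.

Three measured compounds differ at one place on a shared core. In an ADME assay on MT4 cells (Homo sapiens) for cytotoxicity, read by MTT assay, with a stated time of 4 days (on this read-out lower numbers stand for higher toxicity in this test and higher numbers for lower toxicity in this test), compound 1 `CCN(C)c1nc(Cc2c(F)cccc2F)c(C)c(=O)[nH]1` gives only a limit, > 85000 nM. Compound 2 `CCCN(C)c1nc(Cc2c(F)cccc2F)c(C)c(=O)[nH]1` also gives only a limit, > 81000 nM. Compound 3 `Cc1c(Cc2c(F)cccc2F)nc(N2CCCCC2)[nH]c1=O` likewise gives only a limit, > 78000 nM. Compound 3 therefore has no numerical reading, and the three cannot be ranked.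

Compound 4 `Cc1c(Cc2c(F)cccc2F)nc(N2CCCCCC2)[nH]c1=O` carries azepan-1-yl in place of piperidin-1-yl on an aromatic carbon, between two ring nitrogen atoms: azepan-1-yl in place of piperidin-1-yl on an aromatic carbon.

Within the data shown here, three measured steps bear on this change. Two alter the same substituent: a step that the two limits leave unreadable from compound 1 to compound 3 and a step that the two limits leave unreadable from compound 2 to compound 3. The third lengthens the chain on that nitrogen: a step that the two limits leave unreadable from compound 1 to compound 2. None of them has a readable size, so they give no direction for the new step. They show only that these three variations all gave limits in this assay and no numerical reading.

No step beyond the scatter is therefore expected, and another limit is the likeliest report. The expected step is an at least 1.0-fold lower number from compound 3 to compound 4 (0.01 log units; that floor lies within the scatter), with no direction implied. For compound 4 the estimated value is 75000 nM, with an expected range from 35000 nM to 100000 nM.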

Compound 4, half-maximal cytotoxic concentration: > 75000 nM
Compound 4 was reported as a limit; the forecaster's own chance of this, stated with the estimate: 75%; the middle value lies on the limit itself.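

In this assay compound 4 gives > 75000 nM, which is a limit and not a number. With compound 1, compound 2 and compound 3 also reported only as limits, none of the steps to compound 4 can be read. The compounds shown leave open whether any substituent at this place on the shared core gives a numerical reading in this assay.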